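This account rests on a few compounds, and the source may have more. Where it says the series, first, only, none or still open, it means among the compounds named here.

Compound 1 `O=C(NC1CCC(O)CC1)N1CCC(c2nc(-c3ccc4ccccc4n3)no2)CC1`: 2700 nM
Compound 2 `O=C(Nc1cccc2cccnc12)N1CCC(c2nc(-c3ccc4ccccc4n3)no2)CC1`: 1400 nM

In a functional assay on Shh Light II cells (Mus musculus) for inhibition, read by a luciferase reporter (on this read-out lower numbers stand for stronger inhibition and higher numbers for weaker inhibition), compound 2, at 1400 nM, lies within the scatter of compound 1, so the two cannot be told apart. Compound 3 `O=C(Nc1ncccc1Cl)N1CCC(c2nc(-c3ccc4ccccc4n3)no2)CC1` differs from compound 2 at one place: 3-chloropyridin-2-yl in place of quinolin-8-yl on an amide-type nitrogen. In words, it has 3-chloropyridin-2-yl in place of quinolin-8-yl on an amide-type nitrogen. Going by the values given here, the only measured change at this nitrogen, a 1.9-fold lower number from compound 1 to compound 2 (0.29 log units; within the scatter), stayed small, so no shift beyond the scatter is expected, although a single step is thin evidence. The estimated change is a 1.3-fold higher number from compound 2 to compound 3 (0.11 log units; within the scatter). Compound 3 is estimated at 1800 nM, with an expected range of 600 nM to 5400 nM.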

Compound 3, half-maximal inhibitory concentration: 2800 nM
For compound 3 the middle estimate is 1.6-fold (0.19 log units) below the measured one; measured number inside the range.
By their numbers in this assay, from the lowest: compounds 2, 1 and 3 (each within the scatter of the next).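

In this assay 3-chloropyridin-2-yl in place of quinolin-8-yl gives (a 2.0-fold higher number from compound 2 to compound 3 (0.30 log units; within the scatter)) and in place of 4-hydroxycyclohexyl gives (a 1.0-fold higher number from compound 1 to compound 3 (0.02 log units; within the scatter)). Three quite different groups on this amide-type nitrogen, with one ring or two, aromatic or not, therefore cannot be told apart by this read-out. Losing the carbon-only aromatic ring of quinolin-8-yl and bringing in a chlorine produce no shift beyond the scatter. As far as these compounds go, whether a small methyl, a carboxylic acid or a longer chain carrying an amine on this nitrogen would move the number stays open. Nothing given here explains why these groups cannot be told apart.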